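Swapping the benzyl ether for a basic side chain

This account rests on a few compounds, and the source may have more. Where it says the series, first, only, none or still open, it means among the compounds named here.

Among the measured compounds shown here, compound 1 `COc1cc2c(Nc3ccc(NC(=O)Nc4ccccc4)cc3)ncnc2cc1OCc1ccccc1` is the only member of this small set with a number rather than a limit. In a functional assay on MCF7 cells (Homo sapiens) for antiproliferative activity, read by MTT assay, with a stated time of 48 h (a higher number here means a weaker inhibitor, a lower number a stronger inhibitor), compound 1 gives 22800 nM. Compound 2 `COc1cc2c(Nc3ccc(NC(=O)Nc4cccc(Cl)c4)cc3)ncnc2cc1OCc1ccccc1` reaches only the limit of the assay, > 50000 nM. Compound 3 `COc1cc2c(Nc3ccc(NC(=O)Nc4ccc(C)c(C)c4)cc3)ncnc2cc1OCc1ccccc1` likewise stops at the limit, > 50000 nM. The two readable steps away from compound 1 both lie on the urea end of the molecule: an at least 2.1-fold higher number from compound 1 to compound 2 (0.34 log units; beyond the scatter) and an at least 2.1-fold higher number from compound 1 to compound 3 (0.34 log units; beyond the scatter), each a loss beyond the scatter, whereas the step that the two limits leave unreadable from compound 2 to compound 3 cannot be read because both of its ends sit at the limit of > 50000 nM in this assay, at which 2 of the 3 values shown sit.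

Compound 4 `COc1cc2c(Nc3ccc(NC(=O)Nc4ccccc4)cc3)ncnc2cc1OCCCN1CCN(C)CC1` alters a different part of the structure: 2-(4-methylpiperazin-1-yl)ethyl in place of phenyl on a saturated chain carbon bound to an oxygen on an aromatic ring. For the measured compounds named here, none of the measured steps touches the ether side of the shared core, so they give no direct guide to the direction of this change. Without a comparable precedent, compound 1 with its 22800 nM is the only anchor, and the estimate is therefore wide. The step of a 1.5-fold lower number from compound 1 to compound 4 (0.18 log units; within the scatter) is expected to be small, within the scatter, in this assay. Compound 4 is thus estimated at 15000 nM, with a range from 4000 nM to 50000 nM.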

Compound 4, half-maximal inhibitory concentration: 29100 nM
For compound 4 the middle estimate is 1.9-fold (0.29 log units) below the measured one, within the range that was stated.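

Among the compounds shown here, this is the first measured change on the ether side of the shared core, and in this assay it shows that this position accepts an exchange of benzyl for 3-(4-methylpiperazin-1-yl)propyl with a 1.3-fold higher number from compound 1 to compound 4 (0.11 log units; within the scatter). An aromatic carbon ring leaves and a non-aromatic ring with 2 hetero atoms enters on a longer chain, yet the two values stay within the scatter of each other, whereas both readable steps on the urea end of the molecule lie beyond it. No information given here accounts for why so large an exchange leaves the read-out within the scatter.

What the compounds shown leave open is whether the piperazine ring itself matters at this position, since a morpholine ring or a simple dimethylamino group on the same propyl chain, or a shorter ethyl or longer butyl chain carrying the 4-methylpiperazine, would separate the ring from the chain length. They also leave open how the 3-(4-methylpiperazin-1-yl)propoxy group behaves when combined with the 3-chlorophenyl or 3,4-dimethylphenyl urea ends, or with a carboxylic acid in place of the amine.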